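Bromo in place of acetyl: a half-life estimate

The compounds below may be only part of what the source reports. "The series", "measured", "known", "first", "only" and "open" are said of these compounds alone.

In a physicochemical assay for pharmacokinetics, read by HPLC, in phosphate buffer, at pH 7.4 (on this read-out higher numbers stand for a longer-lived compound and lower numbers for a shorter-lived compound), compound 1 `CCCC(CCC)C(=O)N(C)/N=N/c1ccc(C(=O)OCC)cc1` gives 34.1 h. Compound 2 `CCCC(CCC)C(=O)N(C)/N=N/c1ccc(C(C)=O)cc1` reads > 40 h, which is a limit of the assay and not a number. Compound 3 `CCCC(CCC)C(=O)N(C)/N=N/c1ccc(Br)cc1` carries bromo in place of acetyl on an aromatic carbon. Within the data shown here, the only measured step, an at least 1.1-fold higher number from compound 1 to compound 2 (0.06 log units; that floor lies within the scatter), has its floor within the scatter and concerns a different exchange, so it offers only weak guidance. No shift beyond the scatter is therefore expected, and the estimated change is an at least 1.3-fold lower number from compound 2 to compound 3 (0.12 log units; that floor lies within the scatter). The estimated half-life of compound 3 is 30 h, with an expected range from 15 h to 60 h.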

Compound 3, half-life: 30.4 h
Beside the measured number, compound 3's estimate is 1.0-fold (0.01 log units) below it; low and high end bracket the measured number.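

Exchanging ethoxycarbonyl for bromo on this aromatic carbon gives a 1.1-fold lower number from compound 1 to compound 3 (0.05 log units; within the scatter), so in this assay a half-life of this size does not depend on a carbonyl group at this position. Exchanging acetyl for bromo gives an at least 1.3-fold lower number from compound 2 to compound 3 (0.11 log units; that floor lies within the scatter). Compound 2 holds a limit of the assay and not a number, so that step is only a floor: the limit of > 40 h in this assay, at which 1 of the 3 values shown sits.

As far as these compounds go, whether an amine or a carboxylic acid on this aromatic carbon would move the half-life beyond the scatter stays open. From the compounds shown here alone, how far compound 2 lies past its limit also stays open.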